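This account rests on a few compounds, and the source may have more. Where it says the series, first, only, none or still open, it means among the compounds named here.

Three compounds have been measured so far:

compound 1, `COc1cc(-c2cc(/C=C/C(=O)c3ccc(N)cc3)[nH]n2)cc(OC)c1OC`, with 92%;
compound 2, `COc1ccc(C(=O)/C=C/c2cc(-c3cc(OC)c(OC)c(OC)c3)n[nH]2)cc1OC`, with 91%;
compound 3, `COc1ccc(-c2cc(/C=C/C(=O)c3ccc(N)cc3)[nH]n2)cc1OC`, with 95%.

All three numbers come from a functional assay on NCI-H522 cells (Homo sapiens) for cytotoxicity, read by sulforhodamine B assay, with a stated time of 48 h, tested at 0.1 uM; a higher number here means a weaker effect of the compound at the concentration tested, a lower number a stronger effect. They lie close together: the step from compound 3 to compound 1 is a number 3 percentage points lower from compound 3 to compound 1 (within the scatter), and the step from compound 1 to compound 2 is a number 1 percentage points lower from compound 1 to compound 2 (within the scatter). Compound 2 has the lowest of the three numbers, but its distance to each of the other two is within the scatter, so no order can be read from these values; all three compounds leave most of the cells unaffected at the concentration tested. Compound 1 differs from compound 3 by methoxy in place of hydrogen on an aromatic carbon. Compound 2 and compound 3 differ in more than one place, and the difference between the two cores is not broken down here.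

The compound still to be measured is compound 4, `COc1cc(C(=O)/C=C/c2cc(-c3cc(OC)c(OC)c(OC)c3)n[nH]2)cc(OC)c1OC`. It differs from compound 2 by methoxy in place of hydrogen on an aromatic carbon. For the measured compounds named here, this is the same change as the one from compound 3 to compound 1, and it sits at the same place, so the earlier step is the best guide. Because that step was a number 3 percentage points lower from compound 3 to compound 1 (within the scatter), the step from compound 2 to compound 4 is expected to be a number 1 percentage points lower from compound 2 to compound 4 (within the scatter), again within the scatter. Compound 4 is therefore estimated at 90%. For compound 4 the expected range runs from 82% to 97%.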

Compound 4, a percentage reported as activity, at one concentration (the size of the read-out at that concentration, not a potency): 103%
Compound 4: middle estimate off by 13 percentage points, on the low side; the measured number lies above the stated range.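

In this assay, placing a methoxy on the aromatic carbon that held a hydrogen gives a number 12 percentage points higher from compound 2 to compound 4 (beyond the scatter), so on this core the added group goes with a weaker effect on the cells at the concentration tested. Set beside the earlier case, the same change does not bring a step of fixed size from one core to the other: the same change on two cores in this assay, a number 3 percentage points lower (within the scatter) from compound 3 to compound 1 and a number 12 percentage points higher (beyond the scatter) from compound 2 to compound 4, 15 percentage points apart, beyond the scatter of two such steps This shows that, within these four compounds, the outcome of adding a methoxy depends on the core that carries it, but with only two such pairs it does not show which part of the core matters, why the steps differ, or what the change would do on a third core.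

The compounds shown carry only methoxy groups and, in two cases, an amino group on their aromatic rings, so it remains open how a hydroxyl group, a chlorine atom or a carboxylic acid at the same place would read in this assay. From the compounds shown here alone, each number also comes from a single concentration at which most cells stay unaffected, so how these compounds would compare at other concentrations remains open as well.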